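The compounds below may be only part of what the source reports. "The series", "measured", "known", "first", "only" and "open" are said of these compounds alone.

Of the compounds shown here, three have so far been measured in an assay on nucleic acid for inhibition of Nucleic Acid, read by fluorescence, tested at 100 uM; a higher number here means more inhibition at the concentration tested (going by the name of the read-out), a lower number less inhibition. Compound 1 `O=C(OC1CCCCC1n1cc(CN2CCC(c3ccccc3)CC2)nn1)c1ccccc1` gives 16%. Compound 2 `O=C(COc1ccccc1)OC1CCCCC1n1cc(CN2CCC(c3ccccc3)CC2)nn1` gives 42%, and compound 3 `CC(C)CCN(C)Cc1cn(C2CCCCC2OC(=O)COc2ccccc2)nn1` gives 59%, the highest of the three, with its gap to each of the other two beyond the scatter.

Compound 2 and compound 1 differ in one place: phenyl in place of phenoxymethyl on a carbonyl carbon. This change brought a number 26 percentage points lower from compound 2 to compound 1 (beyond the scatter), a modest loss of inhibition. Compound 2 and compound 3 differ in more than one place, and the difference between the two cores is not broken down here.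

Compound 4 `CC(C)CCN(C)Cc1cn(C2CCCCC2OC(=O)c2ccccc2)nn1` has not yet been measured. It differs from compound 3 by phenyl in place of phenoxymethyl on a carbonyl carbon, the same change that separates compound 2 from compound 1, now made on the core of compound 3. Among the compounds shown this change occurs twice, and only once with a known outcome.

For compound 4 the expected step in this assay is a number 26 percentage points lower from compound 3 to compound 4 (beyond the scatter), an estimate that rests on the earlier step of a number 26 percentage points lower from compound 2 to compound 1 (beyond the scatter). The cores of the two pairs differ, so the range is kept wide. Compound 4 is accordingly estimated at 33% in this assay, with a likely span from 15% to 52%.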

Compound 4, a percentage reported as inhibition, at one concentration (the size of the read-out at that concentration, not a potency): 26%
Estimate against measurement, compound 4: 7 percentage points above; the range from low to high includes it.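

In this assay, putting phenyl in place of phenoxymethyl on a carbonyl carbon gave a number 33 percentage points lower from compound 3 to compound 4 (beyond the scatter) and so repeated on the core of compound 3 the loss of inhibition already seen on the core of compound 2. Set beside the earlier step, the new one cannot be told apart from it, so in this assay the change carried over from one core to the other with much the same size: the same change on two cores in this assay, a number 26 percentage points lower (beyond the scatter) from compound 2 to compound 1 and a number 33 percentage points lower (beyond the scatter) from compound 3 to compound 4, 7 percentage points apart, within the scatter of two such steps. This shows agreement across two pairs on two cores in a single assay at one concentration, but it does not show that the step would keep its size on any other core, and it does not explain why phenoxymethyl gives more inhibition than phenyl here.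

The compounds shown leave open what other groups on the carbonyl carbon would do, such as a benzyl group, a longer chain ending in phenyl, or a chain carrying a carboxylic acid. Among these compounds, they also leave open how far the amine part alone matters, since no pair differs only there, and a primary amine or a morpholine in that place would be untested ground in this account.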